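Trifluoromethyl to Fluoro on a Quinoline Stilbene Pair

A few compounds are considered here, and "the series" means these few. Any claim that something is new, unique, unknown or untested is made for them only; others in the source may bear on it.

Measured compounds:
Compound 1, `FC(F)(F)c1ccc(/C=C\c2cc3ccc(Cl)cc3nc2Cl)cc1`: 26400 nM
Compound 2, `Fc1ccc(/C=C\c2cc3ccc(Cl)cc3nc2Cl)cc1`: 26900 nM
Compound 3, `COc1ccc2nc(Cl)c(/C=C\c3ccc(C(F)(F)F)cc3)cc2c1`: 40000 nM

In an ADME assay on 184B5 cells (Homo sapiens) for antiproliferative activity, read by sulforhodamine B assay, with a stated time of 72 h (on this read-out higher numbers stand for weaker inhibition and lower numbers for stronger inhibition), compound 1 gives 26400 nM. Compound 2, which differs from it by fluoro in place of trifluoromethyl on an aromatic carbon, gives 26900 nM, so the step from the trifluoromethyl compound to the fluoro compound is a 1.0-fold higher number from compound 1 to compound 2 (0.01 log units; within the scatter). Compound 3 gives 40000 nM; how its core differs from that of compound 1 is not broken down here, and its values stand within the scatter of both compound 1 and compound 2.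

Compound 4, `COc1ccc2nc(Cl)c(/C=C\c3ccc(F)cc3)cc2c1`, has not been measured. It differs from compound 3 by fluoro in place of trifluoromethyl on an aromatic carbon, the same change, at the same place, that turns compound 1 into compound 2. Because that earlier step was a 1.0-fold higher number from compound 1 to compound 2 (0.01 log units; within the scatter), the step from compound 3 to compound 4 is expected to be no change at the digits printed from compound 3 to compound 4 (within the scatter). Compound 4 is therefore estimated to give 40000 nM in this assay, with the expected range running from 20000 nM to 80000 nM.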

Compound 4, half-maximal inhibitory concentration: 19200 nM
Beside the measured number, compound 4's estimate is 2.1-fold (0.32 log units) above it; the measured number lies below the stated range.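

In this assay, fluoro in place of trifluoromethyl on the core of compound 3 appears as a 2.1-fold lower number from compound 3 to compound 4 (0.32 log units; beyond the scatter), a modest step. Set beside the same change on the core of compound 1, the two steps do not differ by more than the scatter of two such steps: the same change on two cores in this assay, a 1.0-fold higher number (0.01 log units; within the scatter) from compound 1 to compound 2 and a 2.1-fold lower number (0.32 log units; beyond the scatter) from compound 3 to compound 4, 2.1-fold (0.33 log units) apart, within the scatter of two such steps The change can therefore be said neither to depend on the core nor to carry over unchanged: it stands beyond the scatter on one core and within it on the other, and two cores are too few to settle the matter.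

The compounds shown leave open how other groups on that aromatic carbon, such as a nitrile, an amine or a carboxylic acid, would read in this assay, as only trifluoromethyl and fluoro stand there. They also leave open whether the step from trifluoromethyl to fluoro would be larger, smaller or absent on a third core.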